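Swapping the Amide-Bound Aryl Group in a Cyclohexyl-Pyridine Series

The source may hold more compounds than are shown below. What is called first, only, known or untested is meant among the compounds shown, and "the series" means these compounds.

Four compounds share one core: a four-membered ring bearing a pentafluorophenyl sulfonyl group, joined through a carbonyl to an amide-type nitrogen that also carries a cyclohexyl-substituted heteroaromatic methyl arm and an aryl group. They were tested in a functional assay on MDA-MB-231 cells (Homo sapiens) for antiproliferative activity, with a stated time of 72 h; on this read-out higher numbers stand for an effect only at larger amounts of compound and lower numbers for an effect already at smaller amounts. Compound 1 `COC(=O)c1ccc(N(Cc2ccc(C3CCCCC3)nc2)C(=O)[C@H]2CCN2S(=O)(=O)c2c(F)c(F)c(F)c(F)c2F)cc1O` gives 2000 nM in this assay. Compound 3 `O=C(NO)c1ccc(N(Cc2cnc(C3CCCCC3)cn2)C(=O)[C@H]2CCN2S(=O)(=O)c2c(F)c(F)c(F)c(F)c2F)cc1O` gives 5200 nM in this assay. The two numbers sit within the usual scatter of each other, so no order between them can be read. Compound 2 `NC(=O)c1ccc(N(Cc2ccc(C3CCCCC3)cn2)C(=O)[C@H]2CCN2S(=O)(=O)c2c(F)c(F)c(F)c(F)c2F)c(F)c1` gives "not determined" (no result reported) in this assay, so it stands nowhere on the numbers shown. Compound 4 `O=C([C@H]1CCN1S(=O)(=O)c1c(F)c(F)c(F)c(F)c1F)N(Cc1ccc(C2CCCCC2)cn1)c1ccc2nn[nH]c2c1` has not yet been measured. It differs from compound 2 in one place: a group of 9 heavy atoms (6 carbon, 3 nitrogen; one five-membered aromatic ring with 3 hetero atoms, one six-membered aromatic ring of carbon only) in place of a group of 10 heavy atoms (7 carbon, 1 nitrogen, 1 oxygen, 1 fluorine; one six-membered aromatic ring of carbon only), on an amide-type nitrogen. For the measured compounds named here, no measured pair differs in one place, so the size of this step cannot be read from the data; the numbers for compound 1 and compound 3 show only that the shared core, with two different aryl groups, reaches the micromolar range. The expected value for compound 4 in this assay is 3000 nM, within a range from 700 nM to 13000 nM.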

Compound 4, half-maximal effective concentration: 6600 nM
Compound 4: the middle estimate sits 2.2-fold (0.34 log units) below what was measured, within the range that was stated.
By their numbers in this assay, from the lowest: compound 1; then compounds 3 and 4 (each within the scatter of the next).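

In this assay compound 4 gives 6600 nM, but compound 2 has no number to compare it with, so no step can be read from this pair. From the compounds shown here alone, what replacing the 4-carbamoyl-2-fluorophenyl group does to this value stays open. Nothing shown bears on a cause.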